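The source may report more compounds than this note shows. Statements on the series, on what has been measured and on what is new or still open speak of the compounds shown alone.

Measured in a functional assay on BXPC-3 cells (Homo sapiens) for antiproliferative activity, read by MTT assay, with a stated time of 48 h; a lower number here means a stronger inhibitor, a higher number a weaker inhibitor:

- compound 1 `Cc1c(C(=O)NCCCN(C)C)oc2ccc(N(Cc3ccc(Br)cc3)S(=O)(=O)c3ccc(Br)cc3)cc12`: 2020 nM
- compound 2 `Cc1c(C(=O)OCCCN(C)C)oc2ccc(N(Cc3ccc(Br)cc3)S(=O)(=O)c3ccc(Br)cc3)cc12`: 24200 nM
- compound 3 `Cc1c(C(=O)NCCS(C)(=O)=O)oc2ccc(N(Cc3ccc(Br)cc3)S(=O)(=O)c3ccc(Br)cc3)cc12`: > 40000 nM (a limit of the assay, not a number)

Only two of these results are true numbers, and compound 2 has the higher of them, so it is the weaker inhibitor of that pair. Compound 3 cannot be ranked as precisely, since its result is a limit.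

Compound 4 `Cc1c(C(=O)NCC(O)CO)oc2ccc(N(Cc3ccc(Br)cc3)S(=O)(=O)c3ccc(Br)cc3)cc12` has (2,3-dihydroxypropyl)amino in place of the 3-(dimethylamino)propoxy of compound 2, on a carbonyl carbon: (2,3-dihydroxypropyl)amino in place of 3-(dimethylamino)propoxy on a carbonyl carbon.

Among the compounds with values here, three measured steps bear on this change. The closest swaps the same group of compound 2 for (2-(methylsulfonyl)ethyl)amino: an at least 1.6-fold higher number from compound 2 to compound 3 (0.21 log units; that floor lies within the scatter). That floor leaves the true size of the step open. The step of a 12-fold higher number from compound 1 to compound 2 (1.08 log units; beyond the scatter) is large and favours the amide-type nitrogen that compound 4 also carries. Against this, an at least 19-fold higher number from compound 1 to compound 3 (1.29 log units; beyond the scatter) is also large and shows that an amide without the dimethylamino end can lose much activity, and compound 4 lacks that end too. Taken together, these steps point to little change or a modest rise in this assay.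

The expected result is a 1.4-fold higher number from compound 2 to compound 4 (0.16 log units; within the scatter), which is no step beyond the scatter. For compound 4 the estimated value is 35000 nM, with an expected range from 14000 nM to 70000 nM.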

Compound 4, half-maximal inhibitory concentration: 27600 nM
For compound 4 the middle estimate is 1.3-fold (0.10 log units) above the measured one; the range from low to high includes it.
By their numbers in this assay, from the lowest: compound 1; then compounds 2 and 4 (each within the scatter of the next). At a limit, above all of these: compound 3.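

In this assay, the step of a 14-fold higher number from compound 1 to compound 4 (1.14 log units; beyond the scatter) is large, so an amide-type nitrogen on this carbonyl carbon does not by itself carry the stronger result of compound 1, which keeps a dimethylamino end that compound 4 lacks. The change from 3-(dimethylamino)propoxy to (2,3-dihydroxypropyl)amino gives a 1.1-fold higher number from compound 2 to compound 4 (0.06 log units; within the scatter) and so leaves the number within the scatter, even though the entering group carries hydrogen-bond donors and the leaving group has none. The step of an at least 1.4-fold lower number from compound 3 to compound 4 (0.16 log units; that floor lies within the scatter) cannot be read for its size, since the result of compound 3 is a limit of the assay and not a number: the limit of > 40000 nM in this assay, at which 1 of the 4 values shown sits.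

As far as these compounds go, it remains open whether the dimethylamino end itself matters or whether other amines would serve as well on the amide, such as a primary amine or a pyrrolidine at the end of the same chain. A shorter or longer chain ending in dimethylamino, or a carboxylic acid on this carbonyl carbon, would show how far the result of compound 1 depends on that exact end group and its distance from the amide.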